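The compounds below may be only part of what the source reports. "The series", "measured", "known", "first", "only" and "open" are said of these compounds alone.

Compound 1 `Nc1ccccc1NC(=O)c1ccc(CSC(=S)N2CCN(c3ccccc3)CC2)cc1` gives 62.2% in a functional assay on HeLa cells (Homo sapiens) for antiproliferative activity, read by CCK-8 assay, with a stated time of 72 h, tested at 2 uM; a higher number here means a stronger effect of the compound at the concentration tested, a lower number a weaker effect. Compound 2 `CN(C(=S)SCc1ccc(C(=O)Nc2ccccc2N)cc1)c1cccnc1` gives 16%. Compound 3 `Nc1ccccc1NC(=O)c1ccc(CSC(=S)N2CCc3cc(Cl)ccc32)cc1` gives 40.1%.

Among these three numbers compound 3 stands second highest. Compound 1 is the nearer neighbour and lies higher, beyond the scatter; compound 2 is the further one and lies lower. The one step that connects two of these compounds by a single change is the one from compound 2 to compound 3: a number 24.1 percentage points higher from compound 2 to compound 3 (beyond the scatter).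

Compound 4 `CN1CCN(C(=S)SCc2ccc(C(=O)Nc3ccccc3N)cc2)CC1` is the next compound and has not yet been measured in this assay. It differs from compound 3 in one place: 4-methylpiperazin-1-yl in place of 5-chloro-2,3-dihydro-1H-indol-1-yl on a thiocarbonyl carbon. Among the measured compounds shown here, the only measured step at that same place, from compound 2 to compound 3, was modest and beyond the scatter. Compound 1, which carries a different group at that place, shows the highest number of the three, while compound 2 shows the lowest, so the numbers span a wide range across groups there. For the measured compounds named here, no step for the change into a 4-methylpiperazin-1-yl group has been measured. Compound 4 is therefore expected to show a step of about a number 5.1 percentage points lower from compound 3 to compound 4 (within the scatter), which is within the scatter. The estimate for compound 4 is 35%, with a range from 10% to 65%.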

Compound 4, a percentage reported as inhibition, at one concentration (the size of the read-out at that concentration, not a potency): 52.6%
Compound 4: middle estimate off by 17.6 percentage points, on the low side; the measured number falls inside the stated range.
By their numbers in this assay, from the lowest: compound 2; then compound 3; then compounds 4 and 1 (each within the scatter of the next).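

The new result shows that the group on the thiocarbonyl carbon need not carry an aromatic ring for activity in this assay: the 4-methylpiperazin-1-yl group, which has none, gives a number 12.5 percentage points higher from compound 3 to compound 4 (beyond the scatter) and a number 36.6 percentage points higher from compound 2 to compound 4 (beyond the scatter), so it outperforms both the 5-chloro-2,3-dihydro-1H-indol-1-yl and methyl(pyridin-3-yl)amino groups. The earlier compounds shown here could not separate the piperazine ring from the phenyl on its amine nitrogen, but the exchange of phenyl for methyl there gives a number 9.6 percentage points lower from compound 1 to compound 4 (within the scatter), so this substituent can change substantially without a change beyond the scatter. Nothing available here explains these differences.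

Still open, on these data alone, is whether the piperazine ring itself matters or whether other saturated rings at the thiocarbonyl carbon, such as morpholine or piperidine, would serve equally well. As far as these compounds go, it is also open whether the amine nitrogen of the piperazine tolerates a bare hydrogen or a larger group such as benzyl, and, since each number is a percentage at one concentration, how these compounds compare in potency.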